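Exchanging one aromatic ring for another in compound 4

The compounds below may be only part of what the source reports. "The series", "measured", "known", "first", "only" and "open" are said of these compounds alone.

Compound 3 `CCS[C@@H]1[C@H](SCC)[C@@H](Cn2cc(-c3ccc(OC)cc3)nn2)O[C@H]1n1cc(C)c(=O)[nH]c1=O` gives 38800 nM in a functional assay on A549 cells (Homo sapiens) for cytotoxicity, read by MTT assay, with a stated time of 72 h (on this read-out higher numbers stand for an effect only at larger amounts of compound and lower numbers for an effect already at smaller amounts), the highest of the two numbers shown. Compound 2 `CCS[C@@H]1[C@H](SCC)[C@@H](Cn2cc(-c3ccccc3)nn2)O[C@H]1n1cc(C)c(=O)[nH]c1=O` gives 31700 nM in this assay, and the step of a 1.2-fold higher number from compound 2 to compound 3 (0.09 log units; within the scatter) shows that the added methoxy changed little. Compound 1 `CCS[C@@H]1[C@H](SCC)[C@@H](Cn2cc(-c3cccs3)nn2)O[C@H]1n1ccc(=O)[nH]c1=O` reports only a limit in this assay, namely >= 100000 nM. Compound 4 `CCS[C@@H]1[C@H](SCC)[C@@H](Cn2cc(-c3cccs3)nn2)O[C@H]1n1cc(C)c(=O)[nH]c1=O` differs from compound 3 by thiophen-2-yl in place of 4-methoxyphenyl on an aromatic carbon. Within the data shown here, no measured step covers this exact exchange; compound 1 carries the same thiophen-2-yl group but lacks the methyl on the shared core, and its result sits at the limit of >= 100000 nM in this assay, at which 1 of the 3 values shown sits. Compound 4 is therefore expected to remain weak, with a step of a 1.5-fold higher number from compound 3 to compound 4 (0.19 log units; within the scatter) that is small or modestly upward. The estimate for compound 4 is 60000 nM, ranging from 25000 nM to 150000 nM.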

Compound 4, half-maximal effective concentration: 37300 nM
The estimate for compound 4 lay 1.6-fold (0.21 log units) above the measured number, and the stated range covers the measured number.
By their numbers in this assay, from the lowest: compounds 2, 4 and 3 (each within the scatter of the next). At a limit, above all of these: compound 1.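

Exchanging 4-methoxyphenyl for thiophen-2-yl gives a 1.0-fold lower number from compound 3 to compound 4 (0.02 log units; within the scatter), and exchanging phenyl for thiophen-2-yl gives a 1.2-fold higher number from compound 2 to compound 4 (0.07 log units; within the scatter), so in this assay these three aromatic groups on this carbon cannot be told apart. The methyl on the shared core, by contrast, gives a clear step, an at least 2.6-fold lower number from compound 1 to compound 4 (0.42 log units; beyond the scatter). The value of compound 1 is a limit: the limit of >= 100000 nM in this assay, at which 1 of the 4 values shown sits.

Still open, on these data alone, is whether a group other than an aromatic ring on this carbon, such as an amine, a carboxylic acid or a longer chain, would shift the number. Also open, as far as these compounds go, is whether the methyl gives a similar step when phenyl or 4-methoxyphenyl replaces thiophen-2-yl.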